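This account rests on a few compounds, and the source may have more. Where it says the series, first, only, none or still open, it means among the compounds named here.

The two measured compounds share one core: compound 1 `CN(C)CCCOc1ccc(C(=O)Nc2ccccc2Oc2ccc(F)cc2)cc1` and compound 2 `CN(C)CCCOc1ccc(C(=O)Nc2ccccc2Oc2ccccc2)cc1`. In an assay on HEK-293T cells for inhibition of Voltage-dependent T-type calcium channel subunit alpha-1H (Homo sapiens), read by calcium flux (a higher number here means a weaker inhibitor, a lower number a stronger inhibitor), compound 1 gives 54000 nM, while compound 2 gives 19000 nM, the lowest of the two numbers, the step being a 2.8-fold lower number from compound 1 to compound 2 (0.45 log units; beyond the scatter). Compound 3 `Cc1cccc(C)c1Oc1ccccc1NC(=O)c1ccc(OCCCN(C)C)cc1` has not been measured. For the measured compounds named here, it differs from compound 2 by 2,6-dimethylphenyl in place of phenyl on an oxygen on an aromatic ring, a change on the same ring that was altered between compound 1 and compound 2, though no measured step puts methyl groups onto that ring. Going by the values given here, the only step that bears on it, a 2.8-fold lower number from compound 1 to compound 2 (0.45 log units; beyond the scatter), was modest, so a step of similar size in this assay seems plausible, with the direction uncertain. Compound 3 is therefore expected to land near 10000 nM, within 3000 nM to 40000 nM, the estimated step being a 1.9-fold lower number from compound 2 to compound 3 (0.28 log units; within the scatter).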

Compound 3, half-maximal inhibitory concentration: 55000 nM
Beside the measured number, compound 3's estimate is 5.5-fold (0.74 log units) below it; measured number above the stated range.
By their numbers in this assay, from the lowest: compound 2; then compounds 1 and 3 (each within the scatter of the next).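

In this assay, this position now responds to a second change: 2,6-dimethylphenyl in place of phenyl on the oxygen gives a step in the opposite direction from the earlier one (a 2.9-fold higher number from compound 2 to compound 3 (0.46 log units; beyond the scatter)). Compound 2, with the plain phenyl, therefore has the lowest number of the three, and neither substituted ring goes against this. Two different rings also read alike here (a 1.0-fold higher number from compound 1 to compound 3 (0.01 log units; within the scatter)), so 4-fluorophenyl and 2,6-dimethylphenyl cannot be told apart in this assay. No evidence is available that accounts for these steps.

The compounds shown leave open whether a single methyl group on this ring would raise the number as well, and whether any ring, such as pyridine, or a cyclohexyl group would bring it below that of compound 2. On these data alone, whether the same order holds with a longer chain in place of the dimethylaminopropoxy group also remains open.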